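Series notes: aryl exchange on the ring amine nitrogen

The source may report more compounds than this note shows. Statements on the series, on what has been measured and on what is new or still open speak of the compounds shown alone.

Measured in an assay on CHO cells for displacement of a labelled ligand from adenosine receptor A1 (Homo sapiens), read by scintillation counting, with a stated time of 120 min, tested at 10 uM; on this read-out higher numbers stand for more inhibition at the one concentration tested (going by the name of the read-out) and lower numbers for less inhibition:
compound 1, `CC(C)N1CCN(Cc2csc(N)c2C(=O)c2ccc(Cl)cc2)CC1`: 0%
compound 2, `Nc1scc(CN2CCN(c3ccc([N+](=O)[O-])cc3)CC2)c1C(=O)c1ccc(Cl)cc1`: 1%

Compound 2 stands highest of the two numbers measured in this assay, with compound 1 nearest; the step of a number 1 percentage points higher from compound 1 to compound 2 (within the scatter) lies within the scatter, so the two numbers give no order. Compound 3, `Nc1scc(CN2CCN(c3ccccc3C(F)(F)F)CC2)c1C(=O)c1ccc(Cl)cc1`, is not yet measured. It differs from compound 2 in one place: 2-(trifluoromethyl)phenyl in place of 4-nitrophenyl on an amine nitrogen in a ring. Among the measured compounds shown here, only one measured step bears on this change: a number 1 percentage points higher from compound 1 to compound 2 (within the scatter), which exchanged isopropyl for 4-nitrophenyl on the same amine nitrogen in a ring and moved nothing beyond the scatter. For the measured compounds named here, no measured step exchanges one aryl group for another on that nitrogen, and no measured compound carries 2-(trifluoromethyl)phenyl. Going by the values given here, with both measured compounds at the low end of the read-out and the single relevant step flat, no step beyond the scatter is expected from a number 2 percentage points higher from compound 2 to compound 3 (within the scatter). For compound 3 the expected value in this assay is 3%, in the range 0% to 15%.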

Compound 3, a percentage reported as inhibition, at one concentration (the size of the read-out at that concentration, not a potency): 0%
For compound 3 the middle estimate is 3 percentage points above the measured one; low and high end bracket the measured number.
By their numbers in this assay, from the lowest: compounds 1, 3 and 2 (each within the scatter of the next).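

In this assay, among the compounds shown here, 2-(trifluoromethyl)phenyl in place of 4-nitrophenyl on the amine nitrogen in a ring gives a number 1 percentage points lower from compound 2 to compound 3 (within the scatter) and is the one exchange of an aryl group for another aryl group at this position, so swapping the whole 4-nitrophenyl group, with its nitro oxygens and hydrogen-bond acceptors, for a fluorine-bearing phenyl leaves the read-out flat. Set against isopropyl, the same aryl group gives no change at the digits printed from compound 1 to compound 3 (within the scatter) and this second aryl group therefore also fails to separate from the alkyl group, leaving all three groups on this nitrogen in the shared core within the scatter of one another, with no compound among them going against that. Nothing on hand accounts for this flat result.

Still open, from the compounds shown here alone, is whether a longer chain on this nitrogen, or a phenyl ring carrying an amine or a carboxylic acid, would move the number beyond the scatter. Also open, going by these compounds, is whether changing the shared core elsewhere, for example replacing the 4-chlorophenyl carbonyl group, would make this position respond at all.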